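Growing the group on the pendant ring: methyl to phenyl

The compounds below may be only part of what the source reports. "The series", "measured", "known", "first", "only" and "open" are said of these compounds alone.

Compound 2 `COc1cc(-n2c(-c3ccc(C)cc3)csc2=S)cc(OC)c1OC` stands at the lower end of the two numbers obtained so far: in a functional assay on MDA-MB-231 cells (Homo sapiens) for cytotoxicity, read by MTT assay, with a stated time of 48 h (on this read-out higher numbers stand for weaker inhibition and lower numbers for stronger inhibition), compound 2 gives 11.8 ug/mL, whereas compound 1 `COc1cc(-n2c(-c3ccccc3)csc2=S)cc(OC)c1OC` gives 52 ug/mL. For the measured compounds named here, the only measured step, a 4.4-fold lower number from compound 1 to compound 2 (0.64 log units; beyond the scatter), came from adding methyl in place of hydrogen on an aromatic carbon.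

Compound 3 `COc1cc(-n2c(-c3ccc(-c4ccccc4)cc3)csc2=S)cc(OC)c1OC` takes that same position one stage further: phenyl in place of methyl on an aromatic carbon. Going by the values given here, no measured pair shows what happens when methyl is exchanged for a whole ring here, so the step from compound 1 to compound 2 is the only guide, and it points toward lower numbers when this position carries a group rather than hydrogen. On that basis compound 3 is expected to give 9 ug/mL in this assay, a step of a 1.3-fold lower number from compound 2 to compound 3 (0.12 log units; within the scatter), with a plausible range from 3 ug/mL to 30 ug/mL.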

Compound 3, half-maximal inhibitory concentration: > 100 ug/mL
Compound 3 gave a limit, no number; the forecaster's own chance of this, stated with the estimate: 5%; at least 11-fold (1.04 log units) between middle value and limit.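

Compound 3 gives a limit of the assay rather than a number: the limit of > 100 ug/mL in this assay, at which 1 of the 3 values shown sits. In this assay, phenyl in place of methyl gives an at least 8.4-fold higher number from compound 2 to compound 3 (0.92 log units; beyond the scatter), so the lower number obtained with methyl on this aromatic carbon does not carry over to a whole ring at the same place. Phenyl in place of hydrogen gives an at least 1.9-fold higher number from compound 1 to compound 3 (0.28 log units; that floor lies within the scatter), and since that floor is within the usual scatter, this pair alone cannot separate phenyl from hydrogen, although the true gap may be wider.

The compounds shown do not tell how far the true value of compound 3 lies from its limit. They also leave open where the change sets in between methyl and phenyl, a question that an ethyl group, a methoxy group or a chlorine atom on this carbon could help to narrow.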